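Moving one methyl: 3,4-dimethylphenyl to 3,5-dimethylphenyl

The compounds below may be only part of what the source reports. "The series", "measured", "known", "first", "only" and "open" are said of these compounds alone.

In an ADME assay on Huh7.5.1 cells (Homo sapiens) for cytotoxicity, read by ATP content, with a stated time of 48 h (on this read-out higher numbers stand for lower toxicity in this test and lower numbers for higher toxicity in this test), compound 2 `Cc1ccc(-c2nc(CN3CCC(C(=O)NCCCN4C[C@H](C)C[C@H](C)C4)CC3)c(C)o2)cc1C` gives 6910 nM and stands lowest of the two numbers, while compound 1 `COc1cccc(Cl)c1-c1nc(CN2CCC(C(=O)NCCCN3C[C@H](C)C[C@H](C)C3)CC2)c(C)o1` gives 15800 nM as the higher one. Compound 3 `Cc1cc(C)cc(-c2nc(CN3CCC(C(=O)NCCCN4C[C@H](C)C[C@H](C)C4)CC3)c(C)o2)c1` carries 3,5-dimethylphenyl in place of 3,4-dimethylphenyl on the shared core, the same atoms joined differently (3,5-dimethylphenyl in place of 3,4-dimethylphenyl on an aromatic carbon). For the measured compounds named here, the one measured step (a 2.3-fold lower number from compound 1 to compound 2 (0.36 log units; beyond the scatter)) was modest and exchanged 2-chloro-6-methoxyphenyl for 3,4-dimethylphenyl, so it offers only a loose guide. No step beyond the scatter is expected in this assay here. The expected step (a 1.1-fold higher number from compound 2 to compound 3 (0.04 log units; within the scatter)) is an estimate that stays within the scatter. Compound 3 is estimated at 7500 nM (4000 nM to 14000 nM).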

Compound 3, half-maximal cytotoxic concentration: 4050 nM
For compound 3 the middle estimate is 1.9-fold (0.27 log units) above the measured one; low and high end bracket the measured number.
By their numbers in this assay, from the lowest: compounds 3 and 2 (each within the scatter of the next); then compound 1.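

In this assay the shift of one methyl gives a 1.7-fold lower number from compound 2 to compound 3 (0.23 log units; within the scatter) and so leaves 3,4-dimethylphenyl and 3,5-dimethylphenyl unresolved on this aromatic carbon. Both dimethylphenyl compounds stand below compound 1, and the exchange of 2-chloro-6-methoxyphenyl for 3,5-dimethylphenyl gives a 3.9-fold lower number from compound 1 to compound 3 (0.59 log units; beyond the scatter) as a modest step beyond the scatter. No evidence here explains either step.

From the compounds shown here alone, whether a single methyl on the phenyl ring, or an amine or carboxylic acid in place of the methyl groups, would give a number apart from these remains open. Which of the two changed groups in compound 1 carries the step also stays unresolved.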